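The source may report more compounds than this note shows. Statements on the series, on what has been measured and on what is new or still open speak of the compounds shown alone.

In a functional assay on HeLa cells (Homo sapiens) for antiproliferative activity, read by MTT assay, with a stated time of 48 h (a lower number here means a stronger inhibitor, a higher number a weaker inhibitor), compound 1 (`Clc1ccccc1CSc1nnc(-c2cnccn2)n1-c1ccccc1`) reports only a limit, > 50000 nM. Compound 2 (`Clc1cccc(CSc2nnc(-c3cnccn3)n2-c2ccccc2)c1`) gives 13500 nM and compound 3 (`Brc1cccc(CSc2nnc(-c3cnccn3)n2-c2ccccc2)c1`) gives 9580 nM. These two stand level, a 1.4-fold lower number from compound 2 to compound 3 (0.15 log units; within the scatter). Compound 4 (`Clc1ccc(CSc2nnc(-c3cnccn3)n2-c2ccccc2)cc1`) differs from compound 3 by 4-chlorophenyl in place of 3-bromophenyl on a saturated chain carbon bound to a sulfur, with 4-chlorophenyl in place of 3-bromophenyl on a saturated chain carbon bound to a sulfur. Replacing 2-chlorophenyl gave the larger steps, an at least 3.7-fold lower number from compound 1 to compound 2 (0.56 log units; beyond the scatter) and an at least 5.2-fold lower number from compound 1 to compound 3 (0.71 log units; beyond the scatter), while the halogen swap gave almost nothing. For the measured compounds named here, no measured step covers 4-chlorophenyl itself, so no change beyond the scatter is expected in this assay. The estimated step is a 1.3-fold higher number from compound 3 to compound 4 (0.10 log units; within the scatter). Compound 4 is expected at 12000 nM, with an estimated range of 4000 nM to 40000 nM.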

Compound 4, half-maximal inhibitory concentration: > 50000 nM
Compound 4 was reported as a limit; the forecaster's own chance of this, stated with the estimate: 15%; at least 4.1-fold (0.61 log units) between middle value and limit.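

In this assay, 4-chlorophenyl brings a clear loss, with an at least 5.2-fold higher number from compound 3 to compound 4 (0.71 log units; beyond the scatter) and an at least 3.7-fold higher number from compound 2 to compound 4 (0.56 log units; beyond the scatter). Of the halogen-bearing groups shown, only 3-chlorophenyl and 3-bromophenyl give a readable number, so a halogen on the phenyl is not enough by itself, and compound 1 and compound 4 go against any such reading. Compound 1 and compound 4 both report only a limit, so the step between them cannot be read: the limit of > 50000 nM in this assay, at which 2 of the 4 values shown sit. Still open, on these data alone, is how far compound 4 lies past its limit, and whether a methoxy group or an amine on the phenyl would give a readable number.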